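Working notes: the step from compound 2 to compound 3

The compounds below may be only part of what the source reports. "The series", "measured", "known", "first", "only" and "open" are said of these compounds alone.

Measured so far in a functional assay on SK-MEL-28 cells (Homo sapiens) for inhibition, read by sulforhodamine B assay, with a stated time of 48 h (a lower number here means a stronger inhibitor of growth, a higher number a weaker inhibitor of growth), for this series:
- compound 1 `COc1cc(-c2nn(-c3cccc(NC(=O)Nc4ccc(Cl)c(Cl)c4)c3)cc2-c2ccncc2)ccc1Cl` gives 1430 nM
- compound 2 `COc1cc(-c2nn(-c3cccc(NC(=O)Nc4cccc(C(F)(F)F)c4)c3)cc2-c2ccncc2)ccc1Cl` gives 1120 nM

Compound 2 stands within the scatter of compound 1, so the two numbers set no order. Going by the values given here, the only measured step is a 1.3-fold lower number from compound 1 to compound 2 (0.11 log units; within the scatter) and it exchanges 3,4-dichlorophenyl for 3-(trifluoromethyl)phenyl on an amide-type nitrogen. The next compound is compound 3 `COc1cc(-c2nn(-c3cccc(NC(=O)c4ccccc4)c3)cc2-c2ccncc2)ccc1Cl` with phenyl in place of (3-(trifluoromethyl)phenyl)amino on a carbonyl carbon. Among the compounds with values here, that single step bears only weakly here, since it kept the amino group that this change removes, and no measured step covers such a removal. A modest move towards a higher number is expected, with little support. The expected size is a 2.2-fold higher number from compound 2 to compound 3 (0.35 log units; beyond the scatter) on this thin evidence. Compound 3 is estimated at 2500 nM with an expected range from 800 nM to 8000 nM for now.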

Compound 3, concentration for 50% growth inhibition: 3860 nM
Beside the measured number, compound 3's estimate is 1.5-fold (0.19 log units) below it, and the stated range covers the measured number.
By their numbers in this assay, from the lowest: compounds 2 and 1 (each within the scatter of the next); then compound 3.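

In this assay, phenyl on the carbonyl carbon in place of (3-(trifluoromethyl)phenyl)amino is a 3.4-fold higher number from compound 2 to compound 3 (0.54 log units; beyond the scatter) and phenyl in place of (3,4-dichlorophenyl)amino is a 2.7-fold higher number from compound 1 to compound 3 (0.43 log units; beyond the scatter) in the same direction. The earlier exchange of one aryl group for another on the amide-type nitrogen stayed within the scatter, whereas removing the amino group together with its aryl substituents moves the number beyond it. No measurement here accounts for this shift.

The compounds shown leave open whether the amino group or the ring substituents carry the difference, as both leave in a single step. A phenyl bearing trifluoromethyl on the carbonyl carbon would separate the two, and a longer chain or a cyclohexyl group at that carbon remains an open comparison.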